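Swapping a Vinyl for Ethynyloxy on a Nucleoside Base

The source may report more compounds than this note shows. Statements on the series, on what has been measured and on what is new or still open speak of the compounds shown alone.

This account concerns a small set of nucleoside-like compounds tested for cytotoxicity in an ADME assay on L1210/0 cells (Mus musculus) for cytotoxicity, with a stated time of 48 h; on this read-out higher numbers stand for weaker inhibition and lower numbers for stronger inhibition. Compound 1, `Cc1ccc(S(=O)(=O)/C=C/[C@H]2O[C@@H](n3cnc4c(N)ncnc43)[C@@H](O)[C@H]2O)cc1`, gives 54000 nM in this assay. Compound 3, `CC(=O)OCCOCn1cnc2c(Cl)nc(I)nc21`, gives 8600 nM. Compound 2, `C=Cc1cn([C@H]2C[C@H](O)[C@@H](CO)O2)c(=O)[nH]c1=O`, gives 14200 nM, which places it second highest of the three numbers: its gap to compound 3 lies within the scatter of the method, while compound 1 shows a number beyond the scatter above it.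

The piece now turns from compound 2 to compound 4, `C#COc1cn([C@H]2C[C@H](O)[C@@H](CO)O2)c(=O)[nH]c1=O`, which has not yet been measured in this assay. The difference between the two structures is ethynyloxy in place of vinyl on an aromatic carbon. The new group sits on an aromatic carbon of a six-membered aromatic ring with two nitrogens, two atoms from the ring nitrogen.

Going by the values given here, no measured pair in this set shows what such a change does, so the expectation rests on compound 2 alone. The step from compound 2 to compound 4 is expected to be small, a 1.4-fold higher number from compound 2 to compound 4 (0.15 log units; within the scatter), with no confident direction and possibly none beyond the scatter. Compound 4 is therefore estimated at 20000 nM, within a range from 4000 nM to 100000 nM.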

Compound 4, half-maximal inhibitory concentration: > 200000 nM
Compound 4: a limit, no number; the forecaster's own chance of this, stated with the estimate: 25%; at least 10-fold (1.00 log units) between middle value and limit.
By their numbers in this assay, from the lowest: compounds 3 and 2 (each within the scatter of the next); then compound 1. At a limit, above all of these: compound 4.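

In this assay, going by these compounds alone, compound 4 reads > 200000 nM, which is a limit of the assay and not a number, and it is the only compound in the set to stand there: the limit of > 200000 nM in this assay, at which 1 of the 4 values shown sits. Ethynyloxy in place of vinyl on an aromatic carbon, two atoms from the ring nitrogen, gives an at least 14-fold higher number from compound 2 to compound 4 (1.14 log units; beyond the scatter), so the step is large and lies beyond the scatter. Within the data shown here, the earlier compounds held no pair differing in one place, which makes this the first reading in the set of how far the cytotoxic read-out responds to the group at this position of the shared core, and it shows that a swap of so few atoms there can weaken inhibition markedly.

The compounds shown cannot tell whether the ether oxygen or the triple bond accounts for the step, and a plain ethynyl, an ethyl or a methoxy group on the same aromatic carbon would be needed to separate the two. Going by these compounds, how an amine or a longer chain would fare at this position also stays open, as does how far the true value of compound 4 lies past its limit.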